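The compounds below may be only part of what the source reports. "The series", "measured", "known", "first", "only" and "open" are said of these compounds alone.

Measured so far:
Compound 1, `CCNCC(=O)Nc1cc(OC)ccc1C(=O)c1cc(OC)c(OC)c(OC)c1`, in a functional assay on HeLa cells (Homo sapiens) for antiproliferative activity, read by MTT assay, with a stated time of 48 h (on this read-out lower numbers stand for stronger inhibition and higher numbers for weaker inhibition), compound 1 gives 2100 nM.
Compound 2, `COc1ccc(C(=O)c2cc(OC)c(OC)c(OC)c2)c(NC(=O)CN(C)C)c1`, in this assay compound 2 gives 470 nM.
Compound 3, `C=C(c1ccc(OC)cc1NC(=O)CNCC)c1ccc(OC)c2c1C=CC(C)(C)O2`, in this assay compound 3 gives 2590 nM.

Compound 1 and compound 2 differ in one place only: dimethylamino in place of ethylamino on a saturated chain carbon bound to a carbonyl carbon. That change produced a 4.5-fold lower number from compound 1 to compound 2 (0.65 log units; beyond the scatter). Compound 3 stands on a different core from compound 1, and the difference between the two cores is not broken down here; the values of compound 1 and compound 3 lie within the scatter of each other, so nothing can be said about their order.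

Compound 4, `C=C(c1ccc(OC)cc1NC(=O)CN(C)C)c1ccc(OC)c2c1C=CC(C)(C)O2`, has not yet been measured. It differs from compound 3 by dimethylamino in place of ethylamino on a saturated chain carbon bound to a carbonyl carbon, the same change, at the same place, that was made between compound 1 and compound 2. For compound 4 the step is expected to be a 3.7-fold lower number from compound 3 to compound 4 (0.57 log units; beyond the scatter) because a 4.5-fold lower number from compound 1 to compound 2 (0.65 log units; beyond the scatter) was seen on the other core. Room is left in that expectation: the step was seen only once and the cores differ. In this assay compound 4 is estimated at 700 nM, with a range from 250 nM to 2500 nM.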

Compound 4, half-maximal inhibitory concentration: 790 nM
Beside the measured number, compound 4's estimate is 1.1-fold (0.05 log units) below it; measured number inside the range.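

In this assay, replacing ethylamino with dimethylamino on the core of compound 3 gave a 3.3-fold lower number from compound 3 to compound 4 (0.52 log units; beyond the scatter), so the change lowered the number on this core as well. Set beside the earlier step, the size of the effect carried over from one core to the other: the same change on two cores in this assay, a 4.5-fold lower number (0.65 log units; beyond the scatter) from compound 1 to compound 2 and a 3.3-fold lower number (0.52 log units; beyond the scatter) from compound 3 to compound 4, 1.4-fold (0.13 log units) apart, within the scatter of two such steps This shows only that one change behaved alike in two matched pairs; it does not show that the same would hold on any further core, and it does not explain why the number falls, even though the count of hydrogen-bond donors drops with this change.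

The compounds shown leave open how far this trend extends along the amine series, for example to an unsubstituted amino group or to diethylamino. They also leave open whether a longer chain between the carbonyl and the dimethylamino group would keep the lower number on either core.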